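Notes on the series: maximal response, compound 3 to compound 4

A few compounds are considered here, and "the series" means these few. Any claim that something is new, unique, unknown or untested is made for them only; others in the source may bear on it.

Compound 1 `CC(C)(C)OC(=O)N1CCC(O[C@H]2CC[C@H](Oc3ccc(S(C)(=O)=O)cc3)CC2)CC1` gives 120% in a functional assay on isolated protein for agonist activity at Glucose-dependent insulinotropic receptor (Rattus norvegicus), read by HTRF and cAMP accumulation; a lower number here means a smaller maximal response, a higher number a larger maximal response.
Compound 2 `CC(C)(C)OC(=O)N1CCC(O[C@H]2CC[C@H](Oc3ccc(C#N)cc3)CC2)CC1` gives 106%.
Compound 3 `C[C@@H](CF)OC(=O)N1CCC(O[C@H]2CC[C@H](Oc3cnc(S(C)(=O)=O)cn3)CC2)CC1` gives 123%.

Of the three numbers, that of compound 3 is the largest, yet its gap to compound 1 lies within the scatter, so the two cannot be ordered; only compound 2 lies beyond the scatter below it.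

Compound 4 `CS(=O)(=O)c1cnc(O[C@H]2CC[C@H](OC3CCN(CC4(C(F)(F)F)CCCC4)CC3)CC2)cn1` has not been measured. It differs from compound 3 as follows: a group of 10 heavy atoms (7 carbon, 3 fluorine; one five-membered non-aromatic ring of carbon only) in place of a group of 7 heavy atoms (4 carbon, 2 oxygen, 1 fluorine; no ring), on an amine nitrogen in a ring.

Among the measured compounds shown here, the one measured step, a number 14 percentage points lower from compound 1 to compound 2 (beyond the scatter), concerns the substituent on an aromatic carbon and not the amine nitrogen in a ring, so it does not bear on this change. For the measured compounds named here, compound 1 and compound 3 differ at the group on that nitrogen and also in the aromatic ring; no single-place step exists for them, and their two values lie within the scatter of each other. Nothing measured here speaks to the ring nitrogen substituent on its own.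

The step expected in this assay is therefore none beyond the scatter, a number 3 percentage points lower from compound 3 to compound 4 (within the scatter). Compound 4 is estimated at 120%, in the range 100% to 140%.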

Compound 4, largest response reached (Emax), in percent of the reference or control that the assay uses: 88%
Beside the measured number, compound 4's estimate is 32 percentage points above it, and the stated range ends above it.
By their numbers in this assay, from the lowest: compound 4; then compound 2; then compounds 1 and 3 (each within the scatter of the next).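

Among the compounds shown here, the group on the amine nitrogen in a ring proves to be a strong control on the maximal response in this assay, with a step of a number 35 percentage points lower from compound 3 to compound 4 (beyond the scatter) for this single change, whereas the only earlier step, a number 14 percentage points lower from compound 1 to compound 2 (beyond the scatter) on an aromatic carbon, said nothing about this nitrogen. Compound 3 and compound 4 share the rest of the structure, including the methylsulfonyl substituent, so that remainder alone does not secure a response like that of compound 3 with 123% and the nitrogen substituent has to be counted as a variable in its own right. The swap changes several things at once, replacing a group with 2 hydrogen-bond acceptors, a double bond and a defined stereocentre by one with 0 hydrogen-bond acceptors, a five-membered carbon ring and three fluorines, and no supporting data on hand account for the lower number.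

Which of these features carries the step remains open, since the ring, the fluorines and the loss of the acceptors all change together. From the compounds shown here alone, a cyclopentylmethyl group without fluorine or a urea on the same nitrogen would help to separate these parts, and the size of the step with the nitrile of compound 2 in place of the methylsulfonyl is also open.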